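Fluoro to chloro on compound 1

The source may report more compounds than this note shows. Statements on the series, on what has been measured and on what is new or still open speak of the compounds shown alone.

Going by the values given here, in a physicochemical assay for lipophilicity, read by HPLC, at pH 7.4 (on this read-out lower numbers stand for lower lipophilicity and higher numbers for higher lipophilicity), compound 1 `C[C@@H](Oc1cc2oc(=O)n(CCC(=O)O)c2cc1Cl)c1ccc(F)cn1` gives 1.98, the lower of the two numbers so far, with compound 2 `C[C@@H](Oc1cc2onc(CCC(=O)O)c2cc1Cl)c1ccc(Cl)cn1` at 2.91, a gap beyond the scatter. Compound 3 `C[C@@H](Oc1cc2oc(=O)n(CCC(=O)O)c2cc1Cl)c1ccc(Cl)cn1` keeps the core of compound 1 and has chloro in place of fluoro on an aromatic carbon. Among the compounds with values here, no measured pair shows this change alone, and compound 2 differs from compound 1 in its core as well. A modest upward step in this assay, beyond the scatter, is expected, estimated at a number 0.47 log units higher from compound 1 to compound 3 (beyond the scatter). Compound 3 is expected at 2.45, with an estimated range of 2.15 to 2.85.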

Compound 3, distribution coefficient: 2.65
Compound 3: middle estimate off by 0.20 log units, on the low side; the range from low to high includes it.
By their numbers in this assay, from the lowest: compound 1; then compounds 3 and 2 (each within the scatter of the next).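

Holding the core of compound 1 fixed, the change from 5-fluoropyridin-2-yl to 5-chloropyridin-2-yl reads in this assay as a number 0.67 log units higher from compound 1 to compound 3 (beyond the scatter) with nothing else altered. This isolates the effect of this one swap at this position, which the earlier pair could not do, as compounds 1 and 2 also differ in their core. Nothing available explains the size of this step.

Still open, as far as these compounds go, is whether the same swap gives a similar step on another core. From the compounds shown here alone, how a bromo, methyl or nitrile group at this position would read in this assay also remains open.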